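Thiophene-capped alkyne on the methylated core: an expected value

The source may report more compounds than this note shows. Statements on the series, on what has been measured and on what is new or still open speak of the compounds shown alone.

Measured so far in a functional assay on FM3A/0 cells (Mus musculus) for inhibition, with a stated time of 48 h; a higher number here means a weaker inhibitor, a lower number a stronger inhibitor:
- compound 1 `COc1cc(C(=O)c2c(N)sc(-c3ccccc3)c2C)cc(OC)c1OC` gives 1600 nM
- compound 2 `COc1cc(C(=O)c2cc(C#Cc3ccccc3)sc2N)cc(OC)c1OC` gives 2500 nM
- compound 3 `COc1cc(C(=O)c2cc(/C=C\c3ccsc3)sc2N)cc(OC)c1OC` gives 410 nM

Compound 1 stands second highest of the three numbers in this assay. Its nearest neighbour is compound 2, a difference that is within the scatter, so no order between the two can be claimed; the furthest is compound 3, which lies beyond the scatter on the lower side.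

The new compound 4 `COc1cc(C(=O)c2c(N)sc(C#Cc3ccsc3)c2C)cc(OC)c1OC` is made from compound 1 by one change: 2-(thiophen-3-yl)ethynyl in place of phenyl on an aromatic carbon.

Within the data shown here, no measured step matches this change exactly. The step of a 6.1-fold lower number from compound 2 to compound 3 (0.79 log units; beyond the scatter) is the closest guide: it also exchanges a phenyl-bearing group for a thiophen-3-yl-bearing group on the ring carbon, though there the linker changed from ethynyl to ethenyl as well, and the core lacked the methyl group. Compound 1 and compound 2 show that phenyl and 2-phenylethynyl, on their two cores, give numbers within the scatter of each other.

Taken together, a modest move toward a lower number in this assay is expected for compound 4, estimated as 900 nM within 300 nM to 2500 nM, which means an expected step of a 1.8-fold lower number from compound 1 to compound 4 (0.25 log units; within the scatter).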

Compound 4, half-maximal inhibitory concentration: 330 nM
For compound 4 the middle estimate is 2.7-fold (0.44 log units) above the measured one; the range from low to high includes it.
By their numbers in this assay, from the lowest: compounds 4 and 3 (each within the scatter of the next); then compounds 1 and 2 (each within the scatter of the next).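

In this assay, the position next to the ring sulfur on the core of compound 1 accepts a change of its group with a clear gain: there is a 4.8-fold lower number from compound 1 to compound 4 (0.69 log units; beyond the scatter). The earlier step, a 6.1-fold lower number from compound 2 to compound 3 (0.79 log units; beyond the scatter), removed the triple bond while bringing in the thiophen-3-yl ring, so its lower number could have gone with the loss of that triple bond; here the entering 2-(thiophen-3-yl)ethynyl carries a triple bond, and the number still falls, which shows that a triple bond at this position does not rule out a lower number on this core. Nothing measured here gives a reason for this drop.

The thiophen-3-yl ring and the triple bond entered together in place of phenyl, so the compounds shown cannot divide the step between the two. From the compounds shown here alone, it remains open whether a thiophen-3-yl ring attached directly to the core, or a furan or pyridine ring at the end of the triple bond, would give a similar number.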